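Does the Same Change Repeat on a Second Core?

The compounds below may be only part of what the source reports. "The series", "measured", "known", "first", "only" and "open" are said of these compounds alone.

Compound 1 `Fc1ccc(/C=N/Nc2nc(-c3cccc(Br)c3)cs2)cc1F` and compound 2 `Fc1ccc(/C=N/Nc2nc(-c3ccc(Br)cc3)cs2)cc1F` share one core and differ by a single change, (4-bromophenyl in place of 3-bromophenyl on an aromatic carbon). In a functional assay on U-87MG ATCC cells for inhibition, with U-87 MG (Homo sapiens) as the target, read by MTT assay, with a stated time of 48 h (on this read-out lower numbers stand for stronger inhibition and higher numbers for weaker inhibition), compound 1 gives 39900 nM. Compound 2 reaches only a limit of the assay, > 100000 nM, rather than a number. The step is an at least 2.5-fold higher number from compound 1 to compound 2 (0.39 log units; beyond the scatter), and it can only be bounded since one of the values sits at a limit (the limit of > 100000 nM in this assay, at which 1 of the 3 values shown sits). Compound 3 `COc1cc(/C=N/Nc2nc(-c3cccc(Br)c3)cs2)c(Br)c(Br)c1OC` carries a different core; how that core differs from the core of compound 1 is not broken down here. In this assay compound 3 gives 27600 nM, close to the value of compound 1. Within the data shown here, compound 4 `COc1cc(/C=N/Nc2nc(-c3ccc(Br)cc3)cs2)c(Br)c(Br)c1OC` is not yet measured; it differs from compound 3 by 4-bromophenyl in place of 3-bromophenyl on an aromatic carbon, the same change in the same surroundings as the one between compound 1 and compound 2. If that change carries over, the expected step is a 2.9-fold higher number from compound 3 to compound 4 (0.46 log units; beyond the scatter), resting on an at least 2.5-fold higher number from compound 1 to compound 2 (0.39 log units; beyond the scatter). Compound 4 is therefore estimated at 80000 nM in this assay, with a range from 40000 nM to 200000 nM, and a fair chance that only a limit is reported.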

Compound 4, half-maximal inhibitory concentration: > 100000 nM
Compound 4 gave a limit, no number; the forecaster's own chance of this, stated with the estimate: 45%; middle value at least 1.2-fold (0.09 log units) away from the limit.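

In this assay, putting 4-bromophenyl in place of 3-bromophenyl on the core of compound 3 gives an at least 3.6-fold higher number from compound 3 to compound 4 (0.55 log units; beyond the scatter), the same direction as on the first core: the same change on two cores in this assay, an at least 2.5-fold higher number (0.39 log units; beyond the scatter) from compound 1 to compound 2 and an at least 3.6-fold higher number (0.55 log units; beyond the scatter) from compound 3 to compound 4; the limit leaves it open whether they differ. Compound 4 reaches only a limit of the assay, > 100000 nM, rather than a number. As far as these compounds go, on these two cores the change therefore carries over in direction, each time beyond the scatter, but two pairs make no general rule, and its true size on either core stays unknown, because the 4-bromophenyl compounds give only limits: the limit of > 100000 nM in this assay, at which 2 of the 4 values shown sit.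

The compounds shown leave open whether the same shift would weaken the read-out with an amine or a carboxylic acid on the phenyl ring in place of the bromine. They also leave open how far beyond the limit compound 2 and compound 4 lie, and so whether the step is larger on one core than on the other.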